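The source may hold more compounds than are shown below. What is called first, only, known or untested is meant among the compounds shown, and "the series" means these compounds.

Working notes on the series.

Of the compounds shown here, two have numbers so far in an assay on isolated protein for inhibition of Rho-associated protein kinase 2 (Homo sapiens), read by a luciferase reporter; on this read-out lower numbers stand for stronger inhibition and higher numbers for weaker inhibition. Compound 1 `O=C(Nc1cc2cc[nH]c(=O)c2cc1Cl)C1CNCC1c1ccccn1` gives 14 nM in this assay. Compound 2 `O=C(Nc1cc2cc[nH]c(=O)c2cc1Cl)[C@@H]1CCCNC1` gives 47 nM in this assay. Of the two, compound 1 has the lower number; the gap to compound 2 lies beyond the scatter, so compound 1 is the stronger inhibitor of the pair on what is known. Among the compounds with values here, no pair among the measured compounds differs in a single place, so no step is available to set a scale for any change.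

The next compound, compound 3 `O=C(Nc1cc2cc[nH]c(=O)c2cc1Cl)C1CNCC1c1cccc(Br)c1`, has not yet been measured in this assay. It differs from compound 1 as follows: 3-bromophenyl in place of pyridin-2-yl on a saturated ring carbon. The group that enters carries no hydrogen-bond acceptor where the group that leaves carried one, and the ring that enters is of carbon only.

With no comparable step shown, the expectation is a step of modest size in this assay, a 1.8-fold higher number from compound 1 to compound 3 (0.25 log units; within the scatter), toward a somewhat higher number for compound 3 than compound 1, though a result within the scatter would not be surprising. The estimate for compound 3 in this assay is 25 nM, with a range from 8 nM to 80 nM.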

Compound 3, half-maximal inhibitory concentration: 2 nM
Compound 3: the middle estimate sits 13-fold (1.10 log units) above what was measured; the measured number lies below the stated range.
By their numbers in this assay, from the lowest: compound 3; then compound 1; then compound 2.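

In this assay, within the data shown here, 3-bromophenyl in place of pyridin-2-yl on a saturated ring carbon gives a 7.0-fold lower number from compound 1 to compound 3 (0.85 log units; beyond the scatter), the first step that can be read, and it lies beyond the scatter. It shows that the number responds to the group carried at this carbon of the five-membered non-aromatic ring, and that a hydrogen-bond acceptor in this group is not required for a low number, since 3-bromophenyl has none and the ring that enters is of carbon only. No measurement shown explains the step, so it stands as an observation for this one pair of compounds.

Going by these compounds, the change removes the pyridine ring nitrogen and adds a bromine in a single step, so the share of each remains unknown; plain phenyl, pyridin-2-yl carrying a bromine, or 3-chlorophenyl would begin to separate them. Also open, on these data alone, is whether bromine is the group that matters on the phenyl ring, or whether a methoxy group, a nitrile or a trifluoromethyl group in its place would give a similar number.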